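This account rests on a few compounds, and the source may have more. Where it says the series, first, only, none or still open, it means among the compounds named here.

Compound 1 `O=C(Nc1cc(C(F)(F)F)cc(C(F)(F)F)c1)c1ccc(Br)cc1O`: 930 nM
Compound 2 `O=C(Nc1cccc(C(F)(F)F)c1)c1cc(F)ccc1O`: 840 nM

In a functional assay on Jurkat cells (Homo sapiens) for cytotoxicity, read by luminescence and CellTiter-Glo, with a stated time of 3 days (a lower number here means a stronger inhibitor, a higher number a weaker inhibitor), only these two compounds have been measured. Compound 2, at 840 nM, lies within the scatter of compound 1, so the two numbers cannot be told apart. Among the measured compounds shown here, no step between them isolates a single change.

Compound 3 `O=C(Nc1cc(C(F)(F)F)cc(C(F)(F)F)c1)c1cc(F)ccc1O` differs from compound 2 by trifluoromethyl in place of hydrogen on an aromatic carbon. The new group stands meta to a large group and meta to a trifluoromethyl group. This gives compound 3 the trifluoromethyl arrangement of compound 1, which reads 930 nM, so no large move is expected. A small shift towards a lower number is expected, perhaps not beyond the scatter, and the estimated size is a 1.4-fold lower number from compound 2 to compound 3 (0.15 log units; within the scatter). The expected value for compound 3 is 600 nM, within an estimated range of 220 nM to 1500 nM.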

Compound 3, half-maximal inhibitory concentration: 500 nM
The estimate for compound 3 lay 1.2-fold (0.08 log units) above the measured number, and the stated range covers the measured number.
By their numbers in this assay, from the lowest: compounds 3, 2 and 1 (each within the scatter of the next).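

In this assay, trifluoromethyl in place of hydrogen on an aromatic carbon, meta to a large group and meta to a trifluoromethyl group, gives a 1.7-fold lower number from compound 2 to compound 3 (0.23 log units; within the scatter). Among the compounds shown here, this is the first single change that can be read at this position, and it shows that the added trifluoromethyl group leaves the number within the scatter. With both trifluoromethyl groups held, 5-fluoro-2-hydroxyphenyl in place of 4-bromo-2-hydroxyphenyl gives a 1.9-fold lower number from compound 1 to compound 3 (0.27 log units; within the scatter), so that exchange cannot be told apart from the scatter either.

The compounds shown leave open whether an amine, a nitrile or a carboxylic acid at this position would shift the number beyond the scatter. They also leave open what a methoxy group in place of the hydroxyl group would do. No measurement given here accounts for these numbers.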